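A few compounds are considered here, and "the series" means these few. Any claim that something is new, unique, unknown or untested is made for them only; others in the source may bear on it.

Measured in a functional assay on KB cells (Homo sapiens) for antiproliferative activity, read by MTT assay, with a stated time of 48 h; on this read-out higher numbers stand for weaker inhibition and lower numbers for stronger inhibition:
- Compound 1 `Cn1cc(C2=C(c3nn(CCCn4cncn4)c4ncccc34)C(=O)N(c3ccccc3)C2=O)c2ccccc21`: > 100000 nM
- Compound 2 `Cn1cc(C2=C(c3nn(CCn4ccnc4)c4ncccc34)C(=O)N(c3ccccc3)C2=O)c2ccccc21`: > 100000 nM
- Compound 3 `Cn1cc(C2=C(c3nn(CCCCn4ccnc4)c4ncccc34)C(=O)NC2=O)c2ccccc21`: > 100000 nM

Compound 3 gives only a limit, > 100000 nM. The whole set stands alike: the limit of > 100000 nM in this assay, at which 3 of the 3 values shown sit.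

Compound 4 `Cn1cc(C2=C(c3nn(CCCCn4ccnc4)c4ncccc34)C(=O)N(c3ccccc3)C2=O)c2ccccc21` differs by phenyl in place of hydrogen on an amide-type nitrogen in a ring.

For the measured compounds named here, the one measured step, a step that the two limits leave unreadable from compound 1 to compound 2, lies in the chain and not at this nitrogen, and it sets no size for this change. Compound 2 already carries phenyl on that nitrogen and gives > 100000 nM, which is a limit. Compound 1 has that phenyl too and gives > 100000 nM, also a limit. No readable step in either direction is therefore expected in this assay.

The estimated step is a number no higher from compound 3 to compound 4 (the limit leaves the size open).

Compound 4 is expected at about 100000 nM, with an estimated range of 30000 nM to 150000 nM.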

Compound 4, half-maximal inhibitory concentration: 47300 nM
The estimate for compound 4 lay 2.1-fold (0.33 log units) above the measured number; the range from low to high includes it.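

In this assay, phenyl in place of hydrogen on the amide-type nitrogen gives an at least 2.1-fold lower number from compound 3 to compound 4 (0.32 log units; beyond the scatter), so this nitrogen bears on the read-out when the chain ends in 1H-imidazol-1-yl. With phenyl held on that nitrogen, the chain and its end group also count, with an at least 2.1-fold lower number from compound 2 to compound 4 (0.32 log units; beyond the scatter) and an at least 2.1-fold lower number from compound 1 to compound 4 (0.32 log units; beyond the scatter). Compound 4 alone gives a number, and the rest of the set stays at a limit: the limit of > 100000 nM in this assay, at which 3 of the 4 values shown sit.

As far as these compounds go, the full size of each step stays open, since each starts from a limit. Also open, from the compounds shown here alone, is how a longer chain, or an amine or carboxylic acid at the chain end, would read with phenyl on that nitrogen.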